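Swapping two chlorines for two fluorines on a chalcone

A few compounds are considered here, and "the series" means these few. Any claim that something is new, unique, unknown or untested is made for them only; others in the source may bear on it.

Two compounds with a shared core, a cinnamoyl-type arm on a pyrazole, have been tested in a functional assay on OVCAR-5 cells (Homo sapiens) for cytotoxicity, read by sulforhodamine B assay, with a stated time of 48 h, tested at 0.01 uM; a higher number here means a weaker effect of the compound at the concentration tested, a lower number a stronger effect. Compound 1, `COc1ccc(-c2cc(/C=C/C(=O)c3ccc(N)cc3)[nH]n2)cc1`, carries an aminophenyl on the carbonyl carbon and in this assay compound 1 gives 99%. Compound 2, `COc1cc(-c2cc(/C=C/C(=O)c3ccc(Cl)c(Cl)c3)[nH]n2)cc(OC)c1OC`, carries a 3,4-dichlorophenyl there instead, and in this assay compound 2 gives 97%. The two numbers sit within the scatter of each other, so neither compound can be called stronger; both leave the cells almost untouched at this concentration.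

Compound 3, `COc1cc(-c2cc(/C=C/C(=O)c3ccc(F)c(F)c3)[nH]n2)cc(OC)c1OC`, has not yet been measured. It differs from compound 2 in one place: 3,4-difluorophenyl in place of 3,4-dichlorophenyl on a carbonyl carbon. For the measured compounds named here, no measured pair shows what this kind of swap does here, so the expectation rests on compound 2 alone. Because compound 2 gives 97%, the step from compound 2 to compound 3 is expected to be no larger than the scatter, no change at the digits printed from compound 2 to compound 3 (within the scatter). Compound 3 is therefore estimated to give about 97%, within a range from 87% to 105%.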

Compound 3, a percentage reported as activity, at one concentration (the size of the read-out at that concentration, not a potency): 99%
Estimate against measurement, compound 3: 2 percentage points below, and the stated range covers the measured number.
By their numbers in this assay, from the lowest: compounds 2, 1 and 3 (each within the scatter of the next).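

For the compounds shown here, exchanging the two chlorines for two fluorines on the phenyl ring attached to the carbonyl carbon gives, in this assay, a number 2 percentage points higher from compound 2 to compound 3 (within the scatter), and this is the first comparison in the set that changes only one place. At this position, then, 3,4-difluorophenyl and 3,4-dichlorophenyl cannot be told apart in this read-out, although the reading comes from a single concentration at which all the compounds shown leave the cells almost untouched, so it does not establish that the two groups would match at a concentration where the cells respond. Nothing measured here bears on why the swap leaves the number within the scatter.

Going by these compounds, whether these two groups would separate at a higher concentration remains open, since a reading at one concentration is not a potency. Also open, on these data alone, is whether a quite different group on the carbonyl carbon, such as a simple alkyl chain or a phenyl ring carrying a carboxylic acid, would move the number beyond the scatter.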